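Removing the phenyl from compound 3: cytotoxicity outlook

The source may hold more compounds than are shown below. What is called first, only, known or untested is meant among the compounds shown, and "the series" means these compounds.

Compound 3 `COC(=O)c1ccc(NCc2cncn2Cc2cccc(-c3ccccc3)c2)cc1-c1ccccc1` carries the 3-phenylphenyl group; in a toxicity assay on NIH3T3 cells (Mus musculus) for cytotoxicity, read by resazurin assay (a higher number here means that more compound is needed for the effect, a lower number that less compound is needed), compound 3 has "not determined" (no result reported), so it stands nowhere on the numbers shown. Compound 4 `COC(=O)c1ccc(NCc2cncn2Cc2ccccc2)cc1-c1ccccc1` differs from it only by hydrogen in place of phenyl on an aromatic carbon. Going by the values given here, no measured step touches this change. The one step shown, a 2.5-fold higher number from compound 1 to compound 2 (0.40 log units; beyond the scatter), concerns a different group on a different part of the molecule: compound 1 `COC(=O)c1ccc(NCc2cncn2Cc2ccccc2Cl)cc1-c1ccccc1` gives 10000 nM, and compound 2 `COC(=O)c1ccc(NCc2cncn2Cc2ccccc2N)cc1-c1ccccc1` gives 25000 nM, both on the shared core that compound 4 keeps. Among the compounds with values here, with no anchor for compound 3 and no step of the same kind, no direction beyond the scatter can be predicted in this assay for compound 4, and the expectation rests on the range spanned by compounds 1 and 2. Compound 4 is expected at 15000 nM, estimated between 5000 nM and 50000 nM.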

Compound 4, half-maximal effective concentration: > 1000 nM
Compound 4 was reported as a limit; the forecaster's own chance of this, stated with the estimate: 25%; the middle value lies beyond the limit too.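

In this assay compound 4 gives a limit, > 1000 nM, so its steps from compound 1 and compound 2 cannot be read. The compounds shown leave open what hydrogen in place of phenyl does in this assay.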